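The source may report more compounds than this note shows. Statements on the series, on what has been measured and on what is new or still open speak of the compounds shown alone.

Compound 1 `CNc1nc(NC2CCCC2)nc(NC2(C#N)CCCCC2)n1` gives > 5000 nM in an in vitro assay on Sf21 cells for inhibition of high affinity 3',5'-cyclic-AMP phosphodiesterase 7A (Homo sapiens) (a higher number here means a weaker inhibitor, a lower number a stronger inhibitor), which is a limit of the assay and not a number. Compound 2 `CNc1nc(NC)nc(NC2(C#N)CCCCC2)n1` gives > 1000 nM in this assay, again only a limit. Compound 3 `CNc1nc(NC2(C#N)CCCCC2)nc(-n2cncn2)n1` gives > 5000 nM in this assay, also a limit.

Compound 3 therefore stands at the upper boundary of what this assay reports, shared with compound 1 (the limit of > 5000 nM in this assay, at which 2 of the 3 values shown sit), while compound 2 sits at a lower boundary (the limit of > 1000 nM in this assay, at which 1 of the 3 values shown sits). The steps a step that the two limits leave unreadable from compound 1 to compound 3 and a step that the two limits leave unreadable from compound 2 to compound 3 cannot be sized from these limits. Compound 4 `CNc1nc(NC2(C#N)CCCCC2)nc(-n2ccnc2)n1` differs from compound 3 by 1H-imidazol-1-yl in place of 1H-1,2,4-triazol-1-yl on an aromatic carbon. Among the compounds with values here, no measured step concerns such an exchange, so no step size can be read off. Compound 4 is expected to remain at the limit, estimated at 8000 nM within 2000 nM to 30000 nM. The expected step that the limit leaves unreadable from compound 3 to compound 4 is therefore none beyond the scatter.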

Compound 4, half-maximal inhibitory concentration: 1050 nM
Compound 4: middle estimate off by 7.6-fold (0.88 log units), on the high side, and the stated range ends above it.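

Within the data shown here, compound 4 is the first compound here with a measured number, not a limit, so this position can support inhibition. In this assay, changing 1H-1,2,4-triazol-1-yl to 1H-imidazol-1-yl, two five-membered aromatic rings differing only in their carbon and nitrogen content, gives an at least 4.7-fold lower number from compound 3 to compound 4 (0.67 log units; beyond the scatter), and replacing cyclopentylamino with 1H-imidazol-1-yl gives an at least 4.7-fold lower number from compound 1 to compound 4 (0.67 log units; beyond the scatter). The step from compound 2 cannot be read because compound 2 has only a limit: the limit of > 1000 nM in this assay, at which 1 of the 4 values shown sits.

Which feature of 1H-imidazol-1-yl matters remains open. So does how 1H-pyrazol-1-yl or a dimethylamino group would behave at this carbon.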